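Swapping the benzyl substituent on a urea analogue

The source may hold more compounds than are shown below. What is called first, only, known or untested is meant among the compounds shown, and "the series" means these compounds.

Measured compounds:
compound 1, `Cc1ccc(NC(=S)NC(=O)c2ccc(OCc3cccc(C(F)(F)F)c3)cc2)cc1-c1nc2ccccc2[nH]1`, 15400 nM
compound 2, `Cc1ccc(NC(=S)NC(=O)c2ccc(OCc3ccccc3F)cc2)cc1-c1nc2ccccc2[nH]1`, 6440 nM
compound 3, `Cc1ccc(NC(=O)NC(=O)c2ccc(OCc3cccc(C(F)(F)F)c3)cc2)cc1-c1nc2ccccc2[nH]1`, 9640 nM

Of the compounds shown here, three have been tested in a functional assay on SW-620 cells (Homo sapiens) for inhibition, read by MTT assay, with a stated time of 48 h; a lower number here means a stronger inhibitor, a higher number a weaker inhibitor. Compound 1 gives 15400 nM, compound 2 gives 6440 nM and compound 3 gives 9640 nM. Compounds 1 and 2 share one core, compounds 3 and 4 share another; how the two cores differ is not broken down here. Within the first pair, the change 2-fluorophenyl in place of 3-(trifluoromethyl)phenyl on a saturated chain carbon bound to an oxygen on an aromatic ring produced a 2.4-fold lower number from compound 1 to compound 2 (0.38 log units; beyond the scatter). The values of compound 3 against those of compound 1 and compound 2 lie within the usual scatter, so no ordering among them is claimed.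

Compound 4, `Cc1ccc(NC(=O)NC(=O)c2ccc(OCc3ccccc3F)cc2)cc1-c1nc2ccccc2[nH]1`, has not yet been measured in this assay. It differs from compound 3 by 2-fluorophenyl in place of 3-(trifluoromethyl)phenyl on a saturated chain carbon bound to an oxygen on an aromatic ring, the same kind of change as that from compound 1 to compound 2, made at the same place. On the basis of that single earlier step in this assay, the step from compound 3 to compound 4 is expected to be a 2.1-fold lower number from compound 3 to compound 4 (0.33 log units; beyond the scatter), because compound 1 to compound 2 gave a 2.4-fold lower number from compound 1 to compound 2 (0.38 log units; beyond the scatter). Since this rests on one pair only, and on a different core, the expectation is held loosely. Compound 4 is estimated at 4500 nM, with a likely range from 2000 nM to 10000 nM.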

Compound 4, half-maximal inhibitory concentration: 4110 nM
Compound 4: middle estimate off by 1.1-fold (0.04 log units), on the high side; the measured number falls inside the stated range.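

In this assay, putting 2-fluorophenyl in place of 3-(trifluoromethyl)phenyl on the saturated chain carbon bound to an oxygen on an aromatic ring gave a 2.3-fold lower number from compound 3 to compound 4 (0.37 log units; beyond the scatter), so the change that lowered the number on the core of compound 1 also lowered it on the core of compound 3. The two steps agree in direction and size: the same change on two cores in this assay, a 2.4-fold lower number (0.38 log units; beyond the scatter) from compound 1 to compound 2 and a 2.3-fold lower number (0.37 log units; beyond the scatter) from compound 3 to compound 4, 1.0-fold (0.01 log units) apart, within the scatter of two such steps. Among the compounds shown here, this shows that the change carried over between these two cores as a nearly constant step in this one assay, but with only two pairs it does not establish that the step would hold on any further core, and it cannot tell whether the step comes from losing the trifluoromethyl group or from gaining the fluorine.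

The compounds shown leave open how an unsubstituted phenyl, a chlorophenyl or a methoxyphenyl would behave at the same place on either core, which could help separate those two parts of the change. They also leave open whether the same step would appear in cells other than SW-620, or with an amine or a carboxylic acid on the benzyl ring.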